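Replacing the phenyl of compound 3: working notes

The compounds below may be only part of what the source reports. "The series", "measured", "known", "first", "only" and "open" are said of these compounds alone.

compound 1 `CC1=C(C(=O)Nc2ccc(Cl)cc2)C(c2ccco2)C(C(=O)Nc2ccc(Cl)cc2)=C(C)N1`: 24 ug/mL
compound 2 `CC1=C(C(=O)Nc2ccc(Cl)cc2)C(C/C=C/c2ccccc2)C(C(=O)Nc2ccc(Cl)cc2)=C(C)N1`: 21 ug/mL
compound 3 `COc1ccc(NC(=O)C2=C(C)NC(=O)NC2c2ccccc2)cc1`: 225 ug/mL

All three values come from an ADME assay on Vero cells (Chlorocebus sabaeus) for cytotoxicity, read by sulforhodamine B assay, with a stated time of 3 days; a higher number here means that more compound is tolerated, a lower number that less compound is tolerated. Compound 3, at 225 ug/mL, has the highest of the three numbers, and its gaps to compound 1 and to compound 2 both lie beyond the scatter. The core of compound 3 is not the core shared by the other two.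

Compound 4 `COc1ccc(NC(=O)C2=C(C)NC(=O)NC2c2ccc(O)c(OC)c2)cc1` keeps the core of compound 3 and carries 4-hydroxy-3-methoxyphenyl in place of phenyl on a saturated ring carbon.

Among the measured compounds shown here, only one measured step bears on this change, and only loosely. It is a 1.1-fold lower number from compound 1 to compound 2 (0.06 log units; within the scatter), with 3-phenylprop-2-en-1-yl in place of furan-2-yl on a saturated ring carbon, and it lies within the scatter. For the measured compounds named here, that step belongs to the core of compound 1, and no measured pair tests a substituent on this phenyl. On this thin evidence, no step beyond the scatter is expected in this assay, and no direction is favoured. The estimated change is a 1.1-fold lower number from compound 3 to compound 4 (0.05 log units; within the scatter). For compound 4 the expected value is 200 ug/mL, with an estimated range from 85 ug/mL to 420 ug/mL.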

Compound 4, half-maximal cytotoxic concentration: 8 ug/mL
Compound 4: the middle estimate sits 25-fold (1.40 log units) above what was measured; measured number below the stated range.
By their numbers in this assay, from the lowest: compound 4; then compounds 2 and 1 (each within the scatter of the next); then compound 3.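

In this assay, 4-hydroxy-3-methoxyphenyl in place of phenyl on a saturated ring carbon gives a 28-fold lower number from compound 3 to compound 4 (1.45 log units; beyond the scatter), so on the core of compound 3 the result depends strongly on the group at this position. Among the compounds shown here, the earlier compounds held only one step at such a carbon, on the core of compound 1, and that step, a 1.1-fold lower number from compound 1 to compound 2 (0.06 log units; within the scatter), showed no change beyond the scatter; the new step also shows that the high number of compound 3 does not belong to its core alone, since the same core with the larger group is tolerated far less. Nothing in the data shown gives a reason for this step.

As far as these compounds go, it remains open whether the step follows the hydroxy, the methoxy or the two together, which a phenyl carrying only one of them would separate, and whether an amine or a carboxylic acid on that phenyl would lower the number in the same way. From the compounds shown here alone, it also remains open whether 4-hydroxy-3-methoxyphenyl would give a step of this size on the core of compound 1.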